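Replacing Phenyl with Pyrimidin-2-yl in Compound 1

The source may hold more compounds than are shown below. What is called first, only, known or untested is meant among the compounds shown, and "the series" means these compounds.

Measured so far:
compound 1 `Nc1ccccc1NC(=O)c1ccc(CSC(=S)N2CCN(c3ccccc3)CC2)cc1`: 73.1%
compound 2 `Nc1ccccc1NC(=O)c1ccc(CSC(=S)N(Cc2ccccc2)Cc2ccccc2)cc1`: 18.9%

Of the compounds shown here, two have been tested in a functional assay on HeLa cells (Homo sapiens) for antiproliferative activity, read by CCK-8 assay, with a stated time of 72 h, tested at 8 uM; a lower number here means a weaker effect, a higher number a stronger effect of the compound at the concentration tested. Compound 1 gives 73.1%, and compound 2 gives 18.9%. Of the two numbers, compound 1 stands highest; the gap to compound 2 lies beyond the usual scatter. Among the compounds with values here, the two compounds differ in more than one place, so no single structural step connects them, and their values are simply read side by side.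

Compound 3 `Nc1ccccc1NC(=O)c1ccc(CSC(=S)N2CCN(c3ncccn3)CC2)cc1` has not yet been measured. It differs from compound 1 in exactly one place: pyrimidin-2-yl in place of phenyl on an amine nitrogen in a ring. Within the data shown here, no measured pair shows what a change of this kind does here. Only the value of compound 1 serves as a starting point. The expectation is a modest step, more likely downward than upward, and possibly no step beyond the scatter at all: a number 11.1 percentage points lower from compound 1 to compound 3 (beyond the scatter). Compound 3 is therefore expected to give about 62%, with a range from 35% to 80%.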

Compound 3, a percentage reported as inhibition, at one concentration (the size of the read-out at that concentration, not a potency): 73.9%
Beside the measured number, compound 3's estimate is 11.9 percentage points below it; low and high end bracket the measured number.
By their numbers in this assay, from the lowest: compound 2; then compounds 1 and 3 (each within the scatter of the next).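

In this assay, within the data shown here, putting pyrimidin-2-yl in place of phenyl gives a number 0.8 percentage points higher from compound 1 to compound 3 (within the scatter), which is the first single change read at this position, on an amine nitrogen in the six-membered non-aromatic ring with 2 nitrogen. The exchange keeps the count of 6 heavy atoms and one six-membered aromatic ring, but replaces two ring carbons with nitrogen and goes from 0 to 2 hydrogen-bond acceptors, and at this one concentration compound 1 and compound 3 cannot be told apart. The measurements at hand give no reason for this outcome.

The read-out shows the size of the effect at a single concentration and is not a potency, so compound 1 and compound 3 could still separate at other concentrations. On these data alone, it also remains open whether this nitrogen would give a similar read-out with a group that has no aromatic ring, such as cyclohexyl or a short chain like ethyl, or with a phenyl ring carrying a carboxylic acid.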